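Removing the chloro from the benzyl group of compound 3

A few compounds are considered here, and "the series" means these few. Any claim that something is new, unique, unknown or untested is made for them only; others in the source may bear on it.

Compound 3 `O=S(=O)(NCCCNCc1ccccc1Cl)c1cc(C(F)(F)F)cc(C(F)(F)F)c1` stands at the weak end of the three compounds measured in a functional assay on HPAC cells (Homo sapiens) for inhibition, read by MTT assay, with a stated time of 72 h (a higher number here means a weaker inhibitor of growth, a lower number a stronger inhibitor of growth), where compound 3 gives 10000 nM. Compound 1 `O=S(=O)(NCCCCNCc1ccc(Br)cc1)c1cc(C(F)(F)F)cc(C(F)(F)F)c1` gives 2000 nM in this assay, and compound 2 `COc1ccc(CNCCCNS(=O)(=O)c2cc(C(F)(F)F)cc(C(F)(F)F)c2)cc1OC` gives 3500 nM. The two steps leading to compound 3 are both unfavourable: a 5.0-fold higher number from compound 1 to compound 3 (0.70 log units; beyond the scatter) and a 2.9-fold higher number from compound 2 to compound 3 (0.46 log units; beyond the scatter). Compound 4 `O=S(=O)(NCCCNCc1ccccc1)c1cc(C(F)(F)F)cc(C(F)(F)F)c1` is the next step, and it differs from compound 3 in one place: hydrogen in place of chloro on an aromatic carbon. Neither measured step strips a substituent from the benzyl ring; both exchange one substituted benzyl group for another, so they show only that the 2-chlorobenzyl pattern of compound 3 is the weakest of those tried, not what the bare benzyl group will do. The expectation is therefore a small step, if any, and more likely toward a lower number than a higher one, since compound 3 already holds the highest value. Compound 4 is estimated at 7000 nM, within a range of 3000 nM to 20000 nM, which means an expected step of a 1.4-fold lower number from compound 3 to compound 4 (0.15 log units; within the scatter).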

Compound 4, concentration for 50% growth inhibition: 3200 nM
The estimate for compound 4 lay 2.2-fold (0.34 log units) above the measured number; the measured number falls inside the stated range.
By their numbers in this assay, from the lowest: compounds 1, 4 and 2 (each within the scatter of the next); then compound 3.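

In this assay, among the compounds shown here, this pair gives the first direct reading of the chloro on an aromatic carbon ortho to a large group (a 3.1-fold lower number from compound 3 to compound 4 (0.49 log units; beyond the scatter)), so the high number of compound 3 goes with the chloro and not with the benzyl group as such. With the chloro gone, the two other steps lie within the scatter (a 1.1-fold lower number from compound 2 to compound 4 (0.04 log units; within the scatter); a 1.6-fold higher number from compound 1 to compound 4 (0.20 log units; within the scatter)), and neither the 3,4-dimethoxyphenyl group of compound 2 nor the bromo-bearing, longer-chained benzylamine of compound 1 stands apart from the bare benzyl group of compound 4. No measurement offered here explains what the chloro does at this place.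

As far as these compounds go, whether a fluoro, a methyl or a methoxy on this same aromatic carbon would follow the chloro stays open. Also open, from the compounds shown here alone, is how a bare benzyl group would read on the longer chain of compound 1, where the chain and the bromo differ together.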